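A few compounds are considered here, and "the series" means these few. Any claim that something is new, unique, unknown or untested is made for them only; others in the source may bear on it.

Compound 2 `COc1cc2[nH]c(C)c(-c3ccc(Oc4cccc(OC(F)(F)F)c4)cc3)c(=O)c2cc1Cl` carries a 3-(trifluoromethoxy)phenyl group and was tested in an ADME assay on HepG2 cells (Homo sapiens) for cytotoxicity, read by resazurin assay, with a stated time of 24 h; a higher number here means a weaker inhibitor, a lower number a stronger inhibitor. In this assay compound 2 gives > 10000 nM, which is a limit of the assay rather than a measured number. Compound 1 `COc1cc2[nH]c(C)c(-c3ccc(Oc4ccc(OC(F)(F)F)c(F)c4)cc3)c(=O)c2cc1Cl` gives > 10000 nM, also only a limit. Compound 3 `COc1ccc2c(=O)c(-c3ccc(Oc4ccc(OC(F)(F)F)cc4)cc3)c(C)[nH]c2c1` gives > 10000 nM, again a limit. All three measured compounds thus sit at the same point, (the limit of > 10000 nM in this assay, at which 3 of the 3 values shown sit), so compound 2 cannot be ranked against the other two. Compound 4 `COc1cc2[nH]c(C)c(-c3ccc(Oc4ccc(Cl)cc4)cc3)c(=O)c2cc1Cl` has not yet been measured; it differs from compound 2 by 4-chlorophenyl in place of 3-(trifluoromethoxy)phenyl on an oxygen on an aromatic ring. Because every measured compound sits at the limit of > 10000 nM in this assay, at which 3 of the 3 values shown sit, the step that the limit leaves unreadable from compound 2 to compound 4 is expected to be none beyond the usual scatter. Compound 4 is therefore estimated at 15000 nM, with a range from 7000 nM to 40000 nM, most likely reported once more only as a limit.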

Compound 4, half-maximal inhibitory concentration: > 10000 nM
Compound 4: only a limit was reported; the forecaster's own chance of this, stated with the estimate: 80%; the middle value is on the limit's open side.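

Among the compounds shown here, no step from compound 2 to compound 4 can be read in this assay, since both compounds are reported only as limits: the limit of > 10000 nM in this assay, at which 4 of the 4 values shown sit. The compounds shown leave open how far beyond that limit each one lies, and so whether 4-chlorophenyl and 3-(trifluoromethoxy)phenyl differ at all here.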